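A few compounds are considered here, and "the series" means these few. Any claim that something is new, unique, unknown or untested is made for them only; others in the source may bear on it.

Measured in an ADME assay on the whole organism for pharmacokinetics, with Rattus norvegicus as the target, in plasma, at a dose of 10 mg/kg; a higher number here means faster removal of the compound, a lower number slower removal:
compound 1 `C[C@H]1CO[C@@H](c2nc(-c3ccc(C(=O)Nc4cc(C(F)(F)F)ccn4)cc3F)c3c(N)nccn23)CN1C(=O)C1CC1` gives 4.2 mL/min/kg
compound 2 `COCC(=O)N1CCO[C@@H](c2nc(-c3ccc(C(=O)Nc4cc(C(F)(F)F)ccn4)cc3F)c3c(N)nccn23)C1` gives 8.2 mL/min/kg

For the measured compounds named here, compound 2 stands at one end of the two numbers, but with only one neighbour: compound 1, from which it is separated by a 2.0-fold higher number from compound 1 to compound 2 (0.29 log units; within the scatter), a step that does not rise above the scatter. No ordering among the two can therefore be claimed.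

Compound 3 `CC(C)C(=O)N1CCO[C@@H](c2nc(-c3ccc(C(=O)Nc4cc(C(F)(F)F)ccn4)cc3F)c3c(N)nccn23)C1` differs from compound 2 by isopropyl in place of methoxymethyl on a carbonyl carbon. Going by the values given here, the single measured step that bears on this position is a 2.0-fold higher number from compound 1 to compound 2 (0.29 log units; within the scatter), which also exchanged the group on the ring carbonyl (together with a ring methyl) and moved this assay by less than the scatter. The change to compound 3 runs partly back toward compound 1 in so far as the oxygen-bearing methoxymethyl is replaced by an all-carbon group, so, if anything, a slightly lower number than compound 2 is expected, but not a step beyond the scatter; the expected change is a 1.3-fold lower number from compound 2 to compound 3 (0.10 log units; within the scatter). For compound 3 the estimate in this assay is 6.5 mL/min/kg, with a range from 3.2 mL/min/kg to 13 mL/min/kg.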

Compound 3, clearance: 1.4 mL/min/kg
Compound 3: the middle estimate sits 4.6-fold (0.67 log units) above what was measured; the whole stated range lies above it.
By their numbers in this assay, from the lowest: compound 3; then compounds 1 and 2 (each within the scatter of the next).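

In this assay, for the compounds shown here, isopropyl in place of methoxymethyl on the carbonyl carbon gives a 5.9-fold lower number from compound 2 to compound 3 (0.77 log units; beyond the scatter) and is the first step to clear the scatter, so the number does respond to the group at this position. The two groups have the same heavy-atom count and differ in that an oxygen gives way to a carbon, so a change this small in the count is enough to move the number. 4-(isopropylcarbonyl)morpholin-2-yl in place of 4-(cyclopropylcarbonyl)-5-methylmorpholin-2-yl gives a 3.0-fold lower number from compound 1 to compound 3 (0.48 log units; beyond the scatter) as well, which places compound 3 lowest of the three, with both of its steps beyond the scatter, and no measurement at hand gives a reason for either step.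

Going by these compounds alone, only one exchange on this carbonyl carbon has the rest of the structure unchanged, so these compounds cannot separate the loss of the oxygen from the arrival of the branched all-carbon group. A straight propyl chain, or a dimethylaminomethyl group carrying an amine, on the same carbonyl carbon would show which of the two tracks with the number in this assay and how far the trend extends.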